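A few compounds are considered here, and "the series" means these few. Any claim that something is new, unique, unknown or untested is made for them only; others in the source may bear on it.

In a functional assay on FM3A cells (Mus musculus) for antiproliferative activity, with a stated time of 48 h (a lower number here means a stronger inhibitor, a higher number a weaker inhibitor), compound 1 `C=C(Br)C(=O)Nc1ccc(/C=C/C(=O)c2ccc(F)cc2)cc1` gives 1200 nM and compound 2 `C=C(Br)C(=O)Nc1ccc(C(=O)/C=C/c2ccccc2)cc1` gives 690 nM, two values within the usual scatter of each other. Compound 3 `Nc1ccc(/C=C/C(=O)c2ccc(F)cc2)cc1` has a hydrogen in place of the (1-bromoethenyl)carbonyl on the nitrogen of compound 1. Compound 3 gives 185000 nM. That is the highest number of the three, making compound 3 the weakest inhibitor here. Within the data shown here, the only measured step is a 150-fold higher number from compound 1 to compound 3 (2.19 log units; beyond the scatter), and it is large. Compound 4 `Nc1ccc(/C=C/C(=O)c2ccc(I)cc2)cc1` keeps the core of compound 3 but has iodo in place of fluoro on an aromatic carbon, para to a large group: iodo in place of fluoro on an aromatic carbon. The measured step changes the nitrogen, not this carbon, so its size does not carry over. Among the measured compounds shown here, no measured pair compares fluoro with iodo. The step expected in this assay is therefore modest, estimated as a 1.5-fold lower number from compound 3 to compound 4 (0.19 log units; within the scatter), with no clear direction and nothing expected beyond the scatter. For compound 4 the estimated value is 120000 nM, with an expected range from 30000 nM to 300000 nM.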

Compound 4, half-maximal inhibitory concentration: 110000 nM
The estimate for compound 4 lay 1.1-fold (0.04 log units) above the measured number; the measured number falls inside the stated range.
By their numbers in this assay, from the lowest: compounds 2 and 1 (each within the scatter of the next); then compounds 4 and 3 (each within the scatter of the next).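

In this assay, iodo in place of fluoro on an aromatic carbon, para to a large group, gives a 1.7-fold lower number from compound 3 to compound 4 (0.23 log units; within the scatter), so the two halogens cannot be told apart at this position. Among these compounds, this is the first reading at this carbon, and it shows that this exchange, unlike the change on the nitrogen, leaves the number within the usual scatter, with the inhibition still weak. Nothing available explains why the number holds steady across this change.

Still open, from the compounds shown here alone, is whether a different kind of group on this carbon, such as a methoxy group or a nitrile, would move the number beyond the scatter. Going by these compounds, it is also open whether the fluoro and iodo forms would stay as close with (1-bromoethenyl)carbonyl on the nitrogen.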